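Swapping the Aryl Group: Projecting Clearance for Compound 3

This account rests on a few compounds, and the source may have more. Where it says the series, first, only, none or still open, it means among the compounds named here.

Compound 1 `Cc1ncc(C)n2nc(-c3ccn4cc(-c5cccc(Cl)c5)nc4n3)nc12`: 18.9 mL.min-1.g-1
Compound 2 `COc1ccccc1-c1cn2ccc(-c3nc4c(C)ncc(C)n4n3)nc2n1`: 9.1 mL.min-1.g-1

Two compounds have so far been run in an ADME assay on microsomes from liver (Rattus norvegicus) for metabolic stability, read by LC-MS, in the presence of a further agent that is not named here; on this read-out lower numbers stand for slow clearance and higher numbers for fast clearance. Going by the values given here, compound 1 gives 18.9 mL.min-1.g-1, while compound 2 gives 9.1 mL.min-1.g-1, so compound 2 stands lowest of the two numbers, with compound 1 the only neighbour. Among the compounds with values here, the one measured step, a 2.1-fold lower number from compound 1 to compound 2 (0.32 log units; beyond the scatter), came with 2-methoxyphenyl in place of 3-chlorophenyl on an aromatic carbon.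

Compound 3 `Cc1ncc(C)n2nc(-c3ccn4cc(-c5ccc(Br)cc5)nc4n3)nc12` is the next candidate. It differs from compound 2 in one place: 4-bromophenyl in place of 2-methoxyphenyl on an aromatic carbon. Compound 3 thus resembles compound 1 more than compound 2, since both carry a phenyl bearing a single halogen rather than the 2-methoxyphenyl of compound 2. Within the data shown here, the only step that bears on this change is the one from compound 1 to compound 2, which was modest and ran toward a lower number; reversing the 2-methoxyphenyl for a halogen-bearing phenyl points back toward the value of compound 1. The step is therefore expected to be a 1.9-fold higher number from compound 2 to compound 3 (0.27 log units; within the scatter). Compound 3 is estimated at 17 mL.min-1.g-1, within a range of 8 mL.min-1.g-1 to 36 mL.min-1.g-1.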

Compound 3, intrinsic clearance in microsomes: 15 mL.min-1.g-1
The estimate for compound 3 lay 1.1-fold (0.05 log units) above the measured number; measured number inside the range.
By their numbers in this assay, from the lowest: compounds 2, 3 and 1 (each within the scatter of the next, the first and the last beyond it).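

In this assay, 4-bromophenyl in place of 2-methoxyphenyl on this aromatic carbon gives a 1.6-fold higher number from compound 2 to compound 3 (0.22 log units; within the scatter) and so does not clearly separate the two groups, unlike the earlier step between the two other aryl groups, a 2.1-fold lower number from compound 1 to compound 2 (0.32 log units; beyond the scatter), which lay beyond the scatter. The comparison with the 3-chlorophenyl group gives a 1.3-fold lower number from compound 1 to compound 3 (0.10 log units; within the scatter) and also stays within the scatter, so compound 3 cannot be told apart from either earlier compound, even though those two can be told apart from each other. Nothing at hand gives a reason for these numbers.

The step from 3-chlorophenyl to 4-bromophenyl changes both the halogen and its place on the phenyl ring, so the compounds shown do not say what either change does alone, and they leave open how an unsubstituted phenyl would read on the same core. They also leave open how the clearance number would respond to a group of a different kind on this aromatic carbon, such as a pyridine, a morpholine or a phenyl ring carrying a carboxylic acid.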